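This account rests on a few compounds, and the source may have more. Where it says the series, first, only, none or still open, it means among the compounds named here.

Working notes on the series. In a functional assay on HL-60 cells (Homo sapiens) for cytotoxicity, read by MTT assay, with a stated time of 72 h (on this read-out higher numbers stand for weaker inhibition and lower numbers for stronger inhibition), compound 1 `COc1cc(Nc2nc3ccccc3nc2S(=O)(=O)c2ccccc2)cc(OC)c1` gives 50 nM. In this assay compound 2 `COc1cc(Nc2nc3ccccc3nc2S(=O)(=O)c2ccccc2)cc(OC)c1OC` gives 1770 nM, and compound 3 `COc1ccc(S(=O)(=O)c2nc3ccccc3nc2Nc2cccc(N)c2)cc1` gives 1490 nM. Compound 2 stands highest of the three numbers shown: compound 3 lies within the scatter of it, whereas the step of a 35-fold higher number from compound 1 to compound 2 (1.55 log units; beyond the scatter) is well beyond the scatter and stems from a methoxy in place of hydrogen on the aniline ring.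

Compound 4 `COc1cc(Nc2nc3ccccc3nc2S(=O)(=O)c2ccc(Br)cc2)cc(OC)c1OC` differs from compound 2 by bromo in place of hydrogen on an aromatic carbon. Among the compounds with values here, no measured step in this set bears directly on the phenylsulfonyl ring: the single-change step a 35-fold higher number from compound 1 to compound 2 (1.55 log units; beyond the scatter) concerns the other aromatic ring, and compound 3 differs from compound 2 in more than one place, so its value shows only that it sits close to compound 2 in this assay. Within the data shown here, the bromo substitution is thus uncharted in these data, and with no relevant step to lean on the expectation in this assay is no shift beyond the scatter. The expected step of a 1.0-fold higher number from compound 2 to compound 4 (0.01 log units; within the scatter) is accordingly treated as negligible, with a wide range to reflect the lack of precedent. Compound 4 is estimated at 1800 nM, within 600 nM to 5500 nM.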

Compound 4, half-maximal inhibitory concentration: 1020 nM
Estimate against measurement, compound 4: 1.8-fold (0.25 log units) above; the measured number falls inside the stated range.
By their numbers in this assay, from the lowest: compound 1; then compounds 4, 3 and 2 (each within the scatter of the next).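

Within the data shown here, the step of a 1.7-fold lower number from compound 2 to compound 4 (0.24 log units; within the scatter) is the first reading on the phenylsulfonyl ring in this assay, and it shows that phenylsulfonyl to (4-bromophenyl)sulfonyl, with bromo para to a large group, gives no shift beyond the scatter on the background of compound 2. Among these compounds, this position therefore accepts one added bromine atom without a measurable shift here, in contrast to the only single-change step on the other aromatic ring, a 35-fold higher number from compound 1 to compound 2 (1.55 log units; beyond the scatter), which is large. No measurement of any property accompanies this result, so the step stands as a bare observation.

As far as these compounds go, what stays open is whether bromo behaves alike on the far lower-numbered background of compound 1, at 50 nM, as the step is read only on the background of compound 2 with its additional methoxy. Also open, from the compounds shown here alone, is whether another group at this place, such as an amine, a carboxylic acid or a longer chain, would give a step beyond the scatter.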